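The source may hold more compounds than are shown below. What is called first, only, known or untested is meant among the compounds shown, and "the series" means these compounds.

Measured in an ADME assay on MT4 cells (Homo sapiens) for cytotoxicity, read by MTT assay, with a stated time of 96 h; a lower number here means that less compound is tolerated, a higher number that more compound is tolerated:
- compound 1 `c1ccc(/N=N/c2ccc(NC[C@@H]3CCCN4CCCC[C@H]34)c3c2CCCC3)cc1`: 100000 nM
- compound 2 `Fc1ccc(F)c(/N=N/N2CCCC2)c1`: > 100000 nM (a limit)
- compound 3 `Clc1cccc(/N=N/N2CCCCC2)c1`: > 100000 nM (a limit)

Compound 3 has only a limit, > 100000 nM, and no exact number. Compound 2 also has only a limit, > 100000 nM. The series therefore sits high in the range, with the limit of > 100000 nM in this assay, at which 2 of the 3 values shown sit. Within the data shown here, no step between measured compounds is available to size the next change.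

Compound 4 `c1ccc(/N=N/N2CCCCC2)cc1` is still to be measured. It differs from compound 3 by hydrogen in place of chloro on an aromatic carbon. No step beyond the scatter is expected in this assay, and any shift would most likely be small and towards less compound being tolerated. The expected change is an at least 1.2-fold lower number from compound 3 to compound 4 (0.09 log units; that floor lies within the scatter). A further limit is the likeliest report for the next reading. For compound 4 the estimate is 80000 nM, with an expected range of 30000 nM to 100000 nM.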

Compound 4, half-maximal cytotoxic concentration: > 100000 nM
Compound 4 ended at the assay's limit (the forecaster's own chance of this, stated with the estimate: 70%); at least 1.2-fold (0.09 log units) between middle value and limit.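

In this assay compound 3 gives only a limit, > 100000 nM. Compound 4 also gives only a limit, > 100000 nM, so no step can be read between the two. The compounds shown leave open whether hydrogen in place of chloro on an aromatic carbon shifts the reading in this assay at all.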